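The compounds below may be only part of what the source reports. "The series", "measured", "known", "first", "only" and "open" are said of these compounds alone.

Compound 3, `CC(C)c1sc(C(C)C)c(-c2ccc(F)cc2)c1/C=C/[C@@H](O)C[C@@H](O)CC(=O)O`, gives 26 nM in an assay on microsomes for inhibition of 3-hydroxy-3-methylglutaryl-coenzyme A reductase (Rattus norvegicus); a higher number here means a weaker inhibitor, a lower number a stronger inhibitor. Of the two numbers shown it is the higher one; its nearest neighbour is compound 2, `CC(C)=Cc1sc(C(C)C)c(/C=C/[C@@H](O)C[C@@H](O)CC(=O)O)c1-c1ccc(F)cc1`, with 15 nM, and the step of a 1.7-fold higher number from compound 2 to compound 3 (0.24 log units; within the scatter) lies within the scatter. Compound 1, `CC(C)c1sc(-c2ccccc2)c(-c2ccc(-c3ccccc3)cc2)c1/C=C/[C@@H](O)C[C@@H](O)CC(=O)O`, reaches only the limit of the assay at > 10000 nM in this assay; that limit is the limit of > 10000 nM in this assay, at which 1 of the 3 values shown sits.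

Compound 4, `CC(C)c1sc(CO)c(-c2ccc(F)cc2)c1/C=C/[C@@H](O)C[C@@H](O)CC(=O)O`, differs from compound 3 in one place: hydroxymethyl in place of isopropyl on an aromatic carbon. For the measured compounds named here, no measured pair shows this particular exchange. Going by the values given here, the only measured step, a 1.7-fold higher number from compound 2 to compound 3 (0.24 log units; within the scatter), also swaps one group on an aromatic carbon of the shared core and stays within the scatter, so the core tolerates at least that change. A hydroxymethyl group in place of isopropyl has no precedent among these compounds, so the expectation carries a wide range. Compound 4 is expected to give about 60 nM in this assay, between 15 nM and 300 nM. The expected step is a 2.3-fold higher number from compound 3 to compound 4 (0.36 log units; beyond the scatter), a modest move toward a weaker inhibitor.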

Compound 4, half-maximal inhibitory concentration: 325 nM
For compound 4 the middle estimate is 5.4-fold (0.73 log units) below the measured one; measured number outside the range, above it.
By their numbers in this assay, from the lowest: compounds 2 and 3 (each within the scatter of the next); then compound 4. At a limit, above all of these: compound 1.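

In this assay, the step of a 13-fold higher number from compound 3 to compound 4 (1.10 log units; beyond the scatter) and the step of a 22-fold higher number from compound 2 to compound 4 (1.34 log units; beyond the scatter) both show that this position, next to the ring sulfur, does not accept every group. Isopropyl and 2-methylprop-1-en-1-yl lie within the scatter of each other here, whereas hydroxymethyl, which brings a hydrogen-bond donor and acceptor and has one heavy atom fewer than isopropyl, stands well apart from both. Nothing measured here explains this loss.

The compounds shown leave open whether the oxygen or the smaller group counts for more. An ethyl group, a methoxymethyl group and an aminomethyl group on this same carbon would be the comparisons that could separate the two.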